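A Ring Swap in a Flat Cytotoxicity Series

The compounds below may be only part of what the source reports. "The series", "measured", "known", "first", "only" and "open" are said of these compounds alone.

In a functional assay on PC-3 cells (Homo sapiens) for cytotoxicity, read by MTT assay, with a stated time of 72 h (a lower number here means a stronger inhibitor, a higher number a weaker inhibitor), compound 3 `COc1cc2ncnc(Nc3ccc(F)c(Cl)c3)c2cc1NC(=O)N/N=C/c1ccc([N+](=O)[O-])cc1` gives 32400 nM. Compound 1 `O=C(N/N=C/c1ccc([N+](=O)[O-])cc1)Nc1cc2c(Nc3ccc(F)c(Cl)c3)ncnc2cc1O[C@H]1CCOC1` gives 33500 nM and compound 2 `COc1cc(/C=N/NC(=O)Nc2cc3c(Nc4ccc(F)c(Cl)c4)ncnc3cc2O[C@H]2CCOC2)cc(OC)c1OC` gives 29600 nM, which places all three within the scatter of one another, with no distinct rank for compound 3. Compound 4 `COc1cc2ncnc(Nc3ccc(F)c(Cl)c3)c2cc1NC(=O)N/N=C/c1cc(Br)c(O)c(Br)c1` differs from compound 3 in one place, on a carbon with a double bond to nitrogen: 3,5-dibromo-4-hydroxyphenyl in place of 4-nitrophenyl (3,5-dibromo-4-hydroxyphenyl in place of 4-nitrophenyl on a carbon with a double bond to nitrogen). The closest measured change replaces the same 4-nitrophenyl with 3,4,5-trimethoxyphenyl, giving a 1.1-fold lower number from compound 1 to compound 2 (0.05 log units; within the scatter), within the scatter. The change of oxolan-3-yl to methyl on an oxygen on an aromatic ring, a 1.0-fold lower number from compound 1 to compound 3 (0.01 log units; within the scatter), also stays within the scatter. Among the measured compounds shown here, no measured compound carries 3,5-dibromo-4-hydroxyphenyl, and the range must stay wide. Going by the step of a 1.1-fold lower number from compound 1 to compound 2 (0.05 log units; within the scatter), no step beyond the scatter is expected in this assay, in either direction. The expected step is a 1.2-fold lower number from compound 3 to compound 4 (0.08 log units; within the scatter). For compound 4 the estimated value is 27000 nM, with an expected range of 9000 nM to 60000 nM.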

Compound 4, half-maximal inhibitory concentration: 41500 nM
Estimate against measurement, compound 4: 1.5-fold (0.19 log units) below; the range from low to high includes it.
By their numbers in this assay, from the lowest: compounds 2, 3, 1 and 4 (each within the scatter of the next).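

In this assay the replacement of 4-nitrophenyl by 3,5-dibromo-4-hydroxyphenyl on the carbon with a double bond to nitrogen gives a 1.3-fold higher number from compound 3 to compound 4 (0.11 log units; within the scatter) and so does not leave the scatter. Among the compounds shown here, this place had so far been tested only with the oxolan-3-yl ether, whereas this step shows the same flat result with the methyl ether, for an entering ring that carries bromine and a hydrogen-bond donor. No measurement at hand accounts for this flat result.

From the compounds shown here alone, it remains open whether 3,5-dibromo-4-hydroxyphenyl behaves the same way with oxolan-3-yl on the oxygen. Going by these compounds, it is also open whether any group on this carbon, such as a ring bearing an amine or a carboxylic acid, or a longer chain, would produce a step beyond the scatter.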